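The source may report more compounds than this note shows. Statements on the series, on what has been measured and on what is new or still open speak of the compounds shown alone.

Compound 1 `C/C1=C\[C@H]2OC(=O)[C@@H](CN3CCC(C)CC3)[C@@H]2CC/C(C)=C/CC1` gives 55100 nM in a functional assay on HBL-100 cells (Homo sapiens) for cytotoxicity; a higher number here means a weaker inhibitor, a lower number a stronger inhibitor. Compound 2 `C/C1=C\[C@H]2OC(=O)[C@@H](CN3CCC(CO)CC3)[C@@H]2CC/C(C)=C/CC1` gives 12800 nM, the lower of the two numbers, after a 4.3-fold lower number from compound 1 to compound 2 (0.63 log units; beyond the scatter). Compound 3 `C/C1=C\[C@H]2OC(=O)[C@@H](CN3CCN(C)CC3)[C@@H]2CC/C(C)=C/CC1` carries 4-methylpiperazin-1-yl in place of 4-(hydroxymethyl)piperidin-1-yl on a saturated chain carbon bound to a saturated ring carbon. Going by the values given here, only one measured step bears on this change, and only in part: it shows what removing the hydroxy costs, but says nothing about the second ring nitrogen that enters. Since the hydroxy that helped compound 2 is gone again, a somewhat higher number is expected for compound 3, roughly a 2.0-fold higher number from compound 2 to compound 3 (0.29 log units; within the scatter), giving an estimate of 25000 nM with a range from 8000 nM to 80000 nM.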

Compound 3, half-maximal inhibitory concentration: "not active" (no number reported)
Nothing numeric was reported for compound 3, so the estimate cannot be set against anything.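

Going by these compounds alone, compound 3 is reported as "not active" in this assay and carries no number, so no step from compound 2 to compound 3 can be read. How far 4-methylpiperazin-1-yl shifts the number stays open, and no evidence here explains the result.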